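The source may report more compounds than this note shows. Statements on the series, on what has been measured and on what is new or still open speak of the compounds shown alone.

The series rests on a shared core, carried in compound 1 `CCCCCCC(CCO)n1cnc2c(NC)ncnc21`, compound 2 `CCCCCCC(CCO)n1cnc2c(N(C)C)ncnc21`, compound 3 `CCCCCCCC(CCO)n1cnc2c(NC)ncnc21` and compound 4 `CCCCCCCC(CCO)n1cnc2c(N(C)C)ncnc21`. The compounds are compared in a functional assay on SW480 cells (Homo sapiens) for antiproliferative activity, read by MTT assay, with a stated time of 48 h; a higher number here means a weaker inhibitor, a lower number a stronger inhibitor. In this assay compound 1 reaches only the limit > 50000 nM. In this assay compound 2 likewise reaches only the limit > 50000 nM. In this assay compound 3 gives 15300 nM.

Compound 2 differs from compound 1 by methyl in place of hydrogen on a nitrogen on an aromatic ring; the step that the two limits leave unreadable from compound 1 to compound 2 cannot be read because both values sit at the limit of > 50000 nM in this assay, at which 2 of the 3 values shown sit. Compound 3 differs from compound 1 by methyl in place of hydrogen on a saturated chain carbon, seven bonds along the chain from an aromatic nitrogen, and here the step is an at least 3.2-fold lower number from compound 1 to compound 3 (0.51 log units; beyond the scatter).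

Compound 4 differs from compound 3 by methyl in place of hydrogen on a nitrogen on an aromatic ring, the same kind of change that turns compound 1 into compound 2, made now on a core that carries the longer chain. The earlier instance gives no readable size, so the expectation for compound 4 rests only on the number of compound 3, 15300 nM, and on the chance that the added methyl on the ring nitrogen weakens rather than strengthens inhibition. Compound 4 is expected to lie near 30000 nM, a step of about a 2.0-fold higher number from compound 3 to compound 4 (0.29 log units; within the scatter), with a fair chance that this assay again reports only a limit.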

Compound 4, half-maximal inhibitory concentration: > 50000 nM
Compound 4 ended at the assay's limit (the forecaster's own chance of this, stated with the estimate: 40%); middle value at least 1.6-fold (0.22 log units) away from the limit.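

In this assay, going by these compounds, the change from methylamino to dimethylamino on the core with the longer chain gives an at least 3.2-fold higher number from compound 3 to compound 4 (0.51 log units; beyond the scatter), and the true size of this step stays unknown, as compound 4 gives only a limit. The same change on the core of compound 1 cannot be read, nor can the chain step between compound 2 and compound 4, since both members of each pair sit at a limit: the limit of > 50000 nM in this assay, at which 3 of the 4 values shown sit. The series therefore shows a loss of inhibition on one core only, and it does not show whether the change carries over to the shorter chain, where the loss could be similar, larger or absent.

The compounds shown leave open whether a still longer chain would lower the number beyond that of compound 3, the only compound here with a measured number. They also leave open how an unsubstituted amine in place of methylamino, or a carboxylic acid in place of the chain's hydroxyl, would fare.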